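A few compounds are considered here, and "the series" means these few. Any claim that something is new, unique, unknown or untested is made for them only; others in the source may bear on it.

Of the compounds shown here, three sharing one core have been measured in a functional assay on thoracic aorta (Rattus norvegicus, strain Wistar), with a stated time of 15 min; on this read-out higher numbers stand for an effect only at larger amounts of compound and lower numbers for an effect already at smaller amounts. Compound 1 (`CCOc1ccc(F)cc1C(C)NC(=O)N(C)S(=O)(=O)c1ccc(C)cc1`) gives 7800 nM, compound 2 (`CCOc1ccc(Br)cc1C(C)NC(=O)N(C)S(=O)(=O)c1ccc(C)cc1`) gives 28600 nM, and compound 3 (`Cc1ccc(S(=O)(=O)N(C)C(=O)NC(C)c2cc(Br)ccc2OC(C)C)cc1`) gives 34700 nM. Compound 2 therefore stands level with compound 3, and both numbers are higher than that of compound 1. Compound 4 (`CCOc1ccc(Br)cc1C(C)NC(=O)NS(=O)(=O)c1ccc(C)cc1`) departs from compound 2 in one place: hydrogen in place of methyl on an amide-type nitrogen. This puts hydrogen in place of methyl on an amide-type nitrogen. Neither measured step touches that nitrogen. Bromo in place of fluoro on an aromatic carbon gave a 3.7-fold higher number from compound 1 to compound 2 (0.56 log units; beyond the scatter), a modest step, while methyl in place of hydrogen on a saturated chain carbon gave a 1.2-fold higher number from compound 2 to compound 3 (0.08 log units; within the scatter). These steps indicate only how large changes in this small set have been, and they give no direction for the new one. No step beyond the scatter is therefore expected in this assay, though this expectation is loosely supported. The estimated step is a 1.1-fold lower number from compound 2 to compound 4 (0.06 log units; within the scatter). For compound 4 the expected value is 25000 nM, with an estimated range from 6000 nM to 80000 nM.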

Compound 4, half-maximal effective concentration: > 300000 nM
Compound 4: only a limit was reported; the forecaster's own chance of this, stated with the estimate: 15%; middle value at least 12-fold (1.07 log units) from the limit.
By their numbers in this assay, from the lowest: compound 1; then compounds 2 and 3 (each within the scatter of the next). At a limit, above all of these: compound 4.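

In this assay, among the compounds shown here, the first change at the amide-type nitrogen whose other neighbours are the carbonyl carbon and the sulfonyl sulfur, hydrogen in place of methyl, gives an at least 10-fold higher number from compound 2 to compound 4 (1.02 log units; beyond the scatter). For the compounds shown here, that step is large, whereas a 3.7-fold higher number from compound 1 to compound 2 (0.56 log units; beyond the scatter) is modest and a 1.2-fold higher number from compound 2 to compound 3 (0.08 log units; within the scatter) stays within the scatter, so among the places varied here, this nitrogen is the one where a single change of just one methyl counts most. For compound 4, > 300000 nM is a limit of the assay and not a number: the limit of > 300000 nM in this assay, at which 1 of the 4 values shown sits.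

The compounds shown leave open whether an ethyl or a longer chain on this nitrogen would keep, lower or raise the number seen with methyl. They also leave open whether hydrogen in place of methyl would give a step of similar size on compound 1 or on compound 3.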